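The source may hold more compounds than are shown below. What is called first, only, known or untested is meant among the compounds shown, and "the series" means these compounds.

Measured compounds:
- compound 1, `O=C(Nc1ccc(C(F)(F)F)c(Cl)c1)c1cc(Cl)ccc1O`: 690 nM
- compound 2, `O=C(Nc1ccc(Cl)c(Cl)c1)c1cc(F)ccc1O`: 670 nM
- compound 3, `O=C(Nc1ccc(OC(F)(F)F)c(Cl)c1)c1cc(F)ccc1O`: 700 nM

All three were tested in a functional assay on Jurkat cells (Homo sapiens) for cytotoxicity, read by luminescence and CellTiter-Glo, with a stated time of 3 days; on this read-out higher numbers stand for weaker inhibition and lower numbers for stronger inhibition. Compound 3 sits within the scatter of both neighbours: the gap to compound 1 and the gap to compound 2 are each too small to count as a difference, so the three numbers are best read as one level.

Compound 4, `O=C(Nc1ccc(OC(F)(F)F)c(Cl)c1)c1cc(Cl)ccc1O`, takes the step (chloro in place of fluoro on an aromatic carbon).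

Among the measured compounds shown here, no measured pair changes only this substituent. For the measured compounds named here, the one measured step, a 1.0-fold higher number from compound 2 to compound 3 (0.02 log units; within the scatter), concerns a different group on the other ring and did not move the number beyond the scatter. Compound 1 and compound 2 differ from each other in two places at once, so their values, which lie within the scatter of each other, show only that the series has so far been flat. Nothing in these data points to a move in either direction.

Compound 4 is therefore expected to stay at the level of the three measured compounds, an estimated 700 nM with a range of 350 nM to 1400 nM. The expected step of no change at the digits printed from compound 3 to compound 4 (within the scatter) is within the scatter.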

Compound 4, half-maximal inhibitory concentration: 840 nM
Compound 4: middle estimate off by 1.2-fold (0.08 log units), on the low side; low and high end bracket the measured number.
By their numbers in this assay, from the lowest: compounds 2, 1, 3 and 4 (each within the scatter of the next).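

In this assay the site on the aromatic carbon para to a hydroxy group can now be read on its own, and chloro in place of fluoro there gives a 1.2-fold higher number from compound 3 to compound 4 (0.08 log units; within the scatter) and so leaves the level of the series unchanged. The compounds before this one offered no single-place comparison at this site, so the flat picture now extends to this position as well as to the group on the other ring, where trifluoromethoxy in place of trifluoromethyl gives a 1.2-fold higher number from compound 1 to compound 4 (0.09 log units; within the scatter) with chloro in place, a second reading alongside the earlier one with fluoro. No other measurement is available that would explain this result.

Every compound shown carries fluoro or chloro at this site, so it remains open whether an amine, a carboxylic acid or a methoxy group there would move the number beyond the scatter. Going by these compounds, all of them also keep the hydroxy group and the amide of the shared core, so what replacing the hydroxy group with a methoxy group would do to the cytotoxicity remains equally open.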